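The compounds below may be only part of what the source reports. "The series", "measured", "known", "first", "only" and "open" are said of these compounds alone.

Measured so far in a functional assay on ZR-75-1 cells (Homo sapiens) for cytotoxicity, read by sulforhodamine B assay, with a stated time of 72 h; on this read-out lower numbers stand for an effect already at smaller amounts and higher numbers for an effect only at larger amounts of compound:
- compound 1 `CCCC[C@H](OC(C)=O)[C@@H](O)[C@H](O)[C@@H]1OC(=O)C=C[C@@H]1OC(C)=O` gives 6.2 ug/mL
- compound 2 `CCCC[C@@H](/C=C\[C@@H]1OC(=O)C[C@@H](OC)[C@@H]1O)OC(C)=O` gives > 20 ug/mL as a limit
- compound 3 `CCCC[C@H](OC(C)=O)[C@@H](OC(C)=O)[C@H](OC(C)=O)[C@H]1CC=CC(=O)O1` gives 8.7 ug/mL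

In this assay compound 3 at 8.7 ug/mL lies within the scatter of compound 1 at 6.2 ug/mL on this read-out. Compound 2 is recorded only as a limit, > 20 ug/mL on this read-out.

The next compound is compound 4 `CCCC[C@H](OC(C)=O)[C@@H](OC(C)=O)[C@H](OC(C)=O)[C@@H]1OC(=O)C=C[C@@H]1OC(C)=O`, reached from compound 3 by a single change: acetoxy in place of hydrogen on a saturated ring carbon, with acetoxy in place of hydrogen on a saturated ring carbon. For the measured compounds named here, no measured pair isolates this change, so the expectation rests on the values alone. With compound 1 at 6.2 ug/mL and compound 3 at 8.7 ug/mL within the scatter of each other, no step beyond the scatter is expected in this assay, with at most a slight lean to a lower number. The estimated step of a 1.3-fold lower number from compound 3 to compound 4 (0.13 log units; within the scatter) therefore stays small. For compound 4 the expected value is 6.5 ug/mL, with an estimated range from 2.5 ug/mL to 16 ug/mL in this series.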

Compound 4, concentration for half-maximal effect: 7.8 ug/mL
For compound 4 the middle estimate is 1.2-fold (0.08 log units) below the measured one, within the range that was stated.
By their numbers in this assay, from the lowest: compounds 1, 4 and 3 (each within the scatter of the next). At a limit, above all of these: compound 2.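

In this assay, acetoxy in place of hydrogen on a saturated ring carbon, two ring bonds from the ring oxygen, gives a 1.1-fold lower number from compound 3 to compound 4 (0.05 log units; within the scatter). For the compounds shown here, the hydrogen at this position can therefore give way to acetoxy with no step beyond the scatter, which the earlier compounds could not show, as no pair among them isolated a single change. Nothing measured here speaks to a cause for this step.

As far as these compounds go, whether a different group at this position, such as an amine or a carboxylic acid, would give a step beyond the scatter stays open. Compound 2 is recorded only as a limit and offers no number for a step: the limit of > 20 ug/mL in this assay, at which 1 of the 4 values shown sits.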